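A few compounds are considered here, and "the series" means these few. Any claim that something is new, unique, unknown or untested is made for them only; others in the source may bear on it.

Measured so far:
- compound 1, `Cn1nc2c(=O)n(CC3(O)CCN(Cc4ccc(-c5ccco5)cc4Cl)CC3)cnc2c1-c1ccc(Cl)cc1`: 143 nM
- compound 2, `Cn1nc2c(=O)n(CC3(O)CCN(Cc4ccc(C5CCCO5)cc4Cl)CC3)cnc2c1-c1ccc(CN)cc1`: 3820 nM
- compound 3, `Cn1nc2c(=O)n(CC3(O)CCN(Cc4ccc(-n5cccn5)cc4Cl)CC3)cnc2c1-c1ccc(CN)cc1`: 233 nM

In an assay on isolated protein for inhibition of ubiquitin carboxyl-terminal hydrolase 7 (Homo sapiens), with stated times of 30 min and 2 h (a lower number here means a stronger inhibitor, a higher number a weaker inhibitor), compound 1 gives the lowest of the three numbers. Its nearest neighbour is compound 3, whose value sits within the usual scatter of compound 1, so the two cannot be ordered. Compound 2 stands far higher than either. Going by the values given here, the one step that changes a single group is a 16-fold lower number from compound 2 to compound 3 (1.21 log units; beyond the scatter); it concerns the far end of the molecule and not the ring altered here.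

Compound 4, `CC(=O)NCc1ccc(-c2c3ncn(CC4(O)CCN(Cc5ccc(-c6ccco6)cc5Cl)CC4)c(=O)c3nn2C)cc1`, differs from compound 1 in one place: acetamidomethyl in place of chloro on an aromatic carbon. Among the compounds with values here, no measured step changes this chloro on its own. Compounds 2 and 3 carry a different group at the same place, but each also differs elsewhere, so only their values can be read: compound 3 lies close to compound 1 in this assay, which suggests a larger, polar group here need not cost much. The step of a 1.8-fold higher number from compound 1 to compound 4 (0.26 log units; within the scatter) is therefore expected to be modest, toward a somewhat higher number. Compound 4 is estimated at 260 nM, with a range from 80 nM to 850 nM.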

Compound 4, half-maximal inhibitory concentration: 46.1 nM
Compound 4: middle estimate off by 5.6-fold (0.75 log units), on the high side, outside the stated range (below it).
By their numbers in this assay, from the lowest: compound 4; then compounds 1 and 3 (each within the scatter of the next); then compound 2.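

In this assay, going by these compounds alone, replacing chloro with acetamidomethyl gives a 3.1-fold lower number from compound 1 to compound 4 (0.49 log units; beyond the scatter), the first step in this set that changes this position alone. The change adds heavy atoms, a hydrogen-bond donor and a hydrogen-bond acceptor, yet the number falls rather than rises, so in this pair the larger group costs nothing in this assay. The compounds shown offer no evidence on what lies behind the step.

Within the data shown here, it remains open whether the carbonyl of the acetamidomethyl group matters, since aminomethyl appears only in compounds 2 and 3, which also differ elsewhere, and no single-change pair sets it against acetamidomethyl. Going by these compounds, how a hydroxymethyl group or a carboxylic acid would compare at this place also remains unknown from these compounds.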